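Amide versus urea at the carbonyl: towards compound 3

The source may hold more compounds than are shown below. What is called first, only, known or untested is meant among the compounds shown, and "the series" means these compounds.

Measured compounds:
compound 1 `COc1cc(-c2nn(-c3cccc(NC(=O)c4cccc(C(F)(F)F)c4)c3)cc2-c2ccncc2)ccc1Cl` — > 50000 nM
compound 2 `COc1cc(-c2nn(-c3cccc(NC(=O)Nc4cccc(C(F)(F)F)c4)c3)cc2-c2ccncc2)ccc1Cl` — 21100 nM

In a functional assay on SK-MEL-28 cells (Homo sapiens) for inhibition, read by sulforhodamine B assay, with a stated time of 48 h (a higher number here means that more compound is tolerated, a lower number that less compound is tolerated), compound 1 reports only the assay limit, > 50000 nM, and not a number. In this assay compound 2 gives 21100 nM. Among the measured compounds shown here, compound 2 therefore holds the only real number in the set; the other entry is a limit (the limit of > 50000 nM in this assay, at which 1 of the 2 values shown sits). For the measured compounds named here, the single measured step is an at least 2.3-fold lower number from compound 1 to compound 2 (0.37 log units; beyond the scatter), an exchange of the amide of compound 1 for the urea of compound 2; its true size is only a lower bound, as one end sits at the limit.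

Compound 3 `COc1cc(-c2nn(-c3cccc(NC(=O)c4ccc(Cl)c(C(F)(F)F)c4)c3)cc2-c2ccncc2)ccc1Cl` is not yet measured. It differs from compound 2 by 4-chloro-3-(trifluoromethyl)phenyl in place of (3-(trifluoromethyl)phenyl)amino on a carbonyl carbon. This restores the amide linkage of compound 1 and carries a chlorine on the aryl group. Going by the values given here, the only measured step bearing on it is an at least 2.3-fold lower number from compound 1 to compound 2 (0.37 log units; beyond the scatter), read in reverse: the amide gave the higher number. Compound 3 is therefore expected to move upward, by a 1.9-fold higher number from compound 2 to compound 3 (0.28 log units; within the scatter). Compound 3 is estimated at 40000 nM, within 15000 nM to 100000 nM, with a fair chance that this assay again reports only a limit.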

Compound 3, concentration lethal to 50% of the cells: > 32500 nM
Compound 3: no number, only a limit; the forecaster's own chance of this, stated with the estimate: 45%; the middle value lies beyond the limit too.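

In this assay compound 3 gives > 32500 nM, which is a limit and not a number. At the carbonyl carbon, exchanging (3-(trifluoromethyl)phenyl)amino for 4-chloro-3-(trifluoromethyl)phenyl gives an at least 1.5-fold higher number from compound 2 to compound 3 (0.18 log units; that floor lies within the scatter), so this change, which alters the linkage and adds a chloro group in one move, is not shown to go beyond the scatter, although its true size may be larger than this floor. The amide now appears with and without the chloro group, both times at a limit, while the urea alone gives a real number; the step between the two amides cannot be read, so the chloro group's contribution remains unresolved.

Open, as far as these compounds go, is how the urea would behave with the 4-chloro-3-(trifluoromethyl)phenyl group, a pairing that would separate the linkage from the chloro group, and how far the two amides actually lie from the urea. Also open, from the compounds shown here alone, is whether a more strongly changed aryl group at this carbonyl, for instance one carrying a carboxylic acid or a dimethylamino group, would bring the amide series into the measurable range of this assay.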